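Pyridine to pyridazine in a methylsulfonyl-bearing series

The compounds below may be only part of what the source reports. "The series", "measured", "known", "first", "only" and "open" are said of these compounds alone.

Compound 1 `CC(C)(C)OC(=O)N1CCC(O[C@H]2CC[C@H](Oc3ccc(S(C)(=O)=O)cn3)CC2)CC1`: 110 nM
Compound 2 `CC(C)OC(=O)N1CCC(O[C@H]2CC[C@H](Oc3ccc(S(C)(=O)=O)nc3)CC2)CC1`: 201 nM

In a functional assay on isolated protein for agonist activity at Glucose-dependent insulinotropic receptor (Rattus norvegicus), read by HTRF and cAMP accumulation (on this read-out higher numbers stand for an effect only at larger amounts of compound and lower numbers for an effect already at smaller amounts), compound 1 gives 110 nM and holds the lowest number of the two, while compound 2 gives 201 nM, a gap that sits within the scatter. Compound 3 `CC(C)(C)OC(=O)N1CCC(O[C@H]2CC[C@H](Oc3ccc(S(C)(=O)=O)nn3)CC2)CC1` has not been measured. It differs from compound 1 in one place: 6-(methylsulfonyl)pyridazin-3-yl in place of 5-(methylsulfonyl)pyridin-2-yl on an oxygen on a saturated carbon. Among the measured compounds shown here, no step between measured compounds shows what this exchange does here. A move of modest size is expected, not clearly beyond the scatter, and if anything toward a higher number. For compound 3 the expected value in this assay is 180 nM, within 60 nM to 550 nM, which is an estimated step of a 1.6-fold higher number from compound 1 to compound 3 (0.21 log units; within the scatter).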

Compound 3, half-maximal effective concentration: 1160 nM
Compound 3: middle estimate off by 6.4-fold (0.81 log units), on the low side, outside the stated range (above it).
By their numbers in this assay, from the lowest: compounds 1 and 2 (each within the scatter of the next); then compound 3.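

In this assay the exchange of 5-(methylsulfonyl)pyridin-2-yl for 6-(methylsulfonyl)pyridazin-3-yl gives an 11-fold higher number from compound 1 to compound 3 (1.02 log units; beyond the scatter) and so shows that this place on an oxygen on a saturated carbon does not tolerate every such ring equally. One ring carbon traded for a nitrogen, with the heavy-atom count unchanged, is enough for a large step. Nothing measured here accounts for that step. Still open, from the compounds shown here alone, is whether an amine or a nitrile in place of the methylsulfonyl on the pyridazine ring would bring the number back down.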